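Working notes on compounds 1 to 4

The compounds below may be only part of what the source reports. "The series", "measured", "known", "first", "only" and "open" are said of these compounds alone.

Measured so far:
compound 1 `CC(=O)Oc1ccccc1C(=O)O[C@H]1CO[C@H]2[C@@H]1OC[C@H]2OC(=O)c1snnc1C` — 0.0642 h
compound 2 `CC(=O)Oc1ccccc1C(=O)O[C@H]1CO[C@H]2[C@@H]1OC[C@H]2O` — 0.055 h
compound 3 `CCC(=O)O[C@@H]1CO[C@H]2[C@@H]1OC[C@@H]2OC(=O)c1ccccc1OC(C)=O` — 0.0608 h

In an ADME assay on a cell-free system (plasma, Homo sapiens) for metabolic stability, with Plasma (Rattus norvegicus) as the target, read by HPLC, at pH 7.4 (on this read-out higher numbers stand for a longer-lived compound and lower numbers for a shorter-lived compound), compound 1 holds the highest of the three numbers, but none of the gaps is more than scatter: a 1.1-fold lower number from compound 1 to compound 3 (0.02 log units; within the scatter) and a 1.2-fold lower number from compound 1 to compound 2 (0.07 log units; within the scatter). Between the other two, a 1.1-fold higher number from compound 2 to compound 3 (0.04 log units; within the scatter). The three compounds are therefore indistinguishable on this read-out.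

Compound 4 `CC(=O)Oc1ccccc1C(=O)O[C@H]1CO[C@H]2[C@@H]1OC[C@H]2OC(=O)c1cnccc1Cl` differs from compound 1 in one place: 4-chloropyridin-3-yl in place of 4-methyl-1,2,3-thiadiazol-5-yl on a carbonyl carbon. Among the compounds with values here, two measured steps touch the same position. The step from compound 1 to compound 3 exchanges the group on that carbonyl carbon for ethyl and stays within scatter; the step from compound 1 to compound 2 removes the whole (4-methyl-1,2,3-thiadiazol-5-yl)carbonyl from the oxygen on the saturated carbon and likewise stays within scatter. Neither keeping, trimming nor removing the group at this position has moved the number, so the step expected for compound 4 is a 1.1-fold lower number from compound 1 to compound 4 (0.03 log units; within the scatter). Compound 4 is therefore estimated at 0.06 h, with a range from 0.035 h to 0.105 h. A chloropyridinyl carbonyl has not been measured here, so the range is kept somewhat wide.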

Compound 4, half-life: 0.0642 h
The estimate for compound 4 lay 1.1-fold (0.03 log units) below the measured number, within the range that was stated.
By their numbers in this assay, from the lowest: compounds 2, 3, 1 and 4 (each within the scatter of the next).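

A second aromatic group on this carbonyl carbon now joins the ethyl and the removal of the whole acyl group already read at this position: exchanging the five-membered ring of 4-methyl-1,2,3-thiadiazol-5-yl for the six-membered ring of 4-chloropyridin-3-yl in this assay gives no change at the digits printed from compound 1 to compound 4 (within the scatter) and brings in a chlorine without any readable effect. Against the non-aromatic comparators, the new group gives a 1.1-fold higher number from compound 3 to compound 4 (0.02 log units; within the scatter) and, with the whole (4-chloropyridin-3-yl)carbonyl in place of hydrogen on the oxygen, a 1.2-fold higher number from compound 2 to compound 4 (0.07 log units; within the scatter), so across these four compounds the half-life does not separate the two aromatic groups, ethyl or the free hydroxyl, and none of the four goes against this. Nothing available bears on why the position behaves in this way.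

On these data alone, whether a carbonyl group carrying an amine, a carboxylic acid or a longer alkyl chain would also stay within the scatter remains open. All four compounds share the rest of the structure, so whether changes elsewhere on the shared core would move the half-life is open as well.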